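From Methoxy to Ethoxy in an Antiproliferative Series

A few compounds are considered here, and "the series" means these few. Any claim that something is new, unique, unknown or untested is made for them only; others in the source may bear on it.

Of the compounds shown here, three have been measured in a functional assay on A2780 cells (Homo sapiens) for antiproliferative activity, read by MTT assay, with a stated time of 48 h; on this read-out higher numbers stand for weaker inhibition and lower numbers for stronger inhibition. Compound 1 `COc1ccc(-c2cncc3[nH]c(=O)n(Cc4cc(OC)c(OC)c(OC)c4)c23)cc1` gives > 20000 nM, which is a limit of the assay and not a number. Compound 2 `COc1ccc(-c2nc3cnccc3n2-c2cc(OC)c(OC)c(OC)c2)cc1O` gives > 20000 nM, again a limit. Going by the values given here, compound 3 `COc1ccc(-c2cc3c(cn2)[nH]c(=O)n3-c2cc(OC)c(OC)c(OC)c2)cc1F` gives 730 nM, the only actual number among the three, while the other two sit at the limit of > 20000 nM in this assay, at which 2 of the 3 values shown sit.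

Compound 4 `CCOc1ccc(-c2cc3c(cn2)[nH]c(=O)n3-c2cc(OC)c(OC)c(OC)c2)cc1F` departs from compound 3 in a single place: methyl in place of hydrogen on a saturated chain carbon bound to an oxygen on an aromatic ring. In other words, methoxy becomes ethoxy, turning 3-fluoro-4-methoxyphenyl into 4-ethoxy-3-fluorophenyl. Among the compounds with values here, no measured pair of compounds here differs in only one place, so the data give no direct precedent for this change. With so small a change, a large shift in this assay is not expected, and any movement would more likely be a slight weakening than a gain. The estimated change a 1.4-fold higher number from compound 3 to compound 4 (0.14 log units; within the scatter) is expected to lie close to the usual scatter. Compound 4 is expected to give 1000 nM, with an estimated range of 300 nM to 4000 nM.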

Compound 4, half-maximal inhibitory concentration: 4330 nM
Estimate against measurement, compound 4: 4.3-fold (0.64 log units) below, and the stated range ends below it.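

In this assay the methyl in place of hydrogen on a saturated chain carbon bound to an oxygen on an aromatic ring is not a silent change: the step reads a 5.9-fold higher number from compound 3 to compound 4 (0.77 log units; beyond the scatter) and so shows that this position responds to one added carbon. Going by these compounds alone, this is the first comparison here between compounds that differ in one place, and it shows methoxy to ethoxy weakening inhibition while compound 4 still gives a measured number and not a limit. Nothing shown here accounts for the size of this loss.

The compounds shown leave open whether a longer chain, such as propoxy, would weaken inhibition further. They also leave open how an amine at this place would compare with methoxy and ethoxy on the same core.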